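The source may hold more compounds than are shown below. What is called first, only, known or untested is meant among the compounds shown, and "the series" means these compounds.

Measured so far:
- compound 1 `Cc1cccc2c(-c3ccc4c(O)cccc4n3)c[nH]c12`: 0.283 h
- compound 2 `Fc1cc2c(-c3ccc4ccccc4n3)c[nH]c2c(F)c1F`: 0.25 h

Of the compounds shown here, two have been measured in an ADME assay on microsomes from liver (Homo sapiens) for metabolic stability, using NADPH, with a stated time of 40 min, tested at 2 uM; on this read-out higher numbers stand for a longer-lived compound and lower numbers for a shorter-lived compound. Compound 1 gives 0.283 h and compound 2 gives 0.25 h; the gap between these two numbers falls within the usual scatter of repeated measurements, so the two compounds cannot be told apart on this read-out. Compound 3 `CNC(=O)c1cccc2nc(-c3c[nH]c4c(C)cccc34)ccc12` has not been measured yet. It shares the core of compound 1 and differs from it in one place: methylcarbamoyl in place of hydroxy on an aromatic carbon. Among the compounds with values here, no pair of measured compounds shows the effect of this kind of change, so there is no directly comparable step to lean on. The step in this assay is expected to be modest, and it is estimated that the change from compound 1 to compound 3 gives a 1.4-fold higher number from compound 1 to compound 3 (0.15 log units; within the scatter). Compound 3 is therefore expected to give about 0.4 h, within a range from 0.15 h to 1 h.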

Compound 3, half-life: 0.983 h
Beside the measured number, compound 3's estimate is 2.5-fold (0.39 log units) below it; the range from low to high includes it.
By their numbers in this assay, from the lowest: compounds 2 and 1 (each within the scatter of the next); then compound 3.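

In this assay this aromatic carbon of the shared core proves able to shift the read-out: methylcarbamoyl in place of hydroxy gives a 3.5-fold higher number from compound 1 to compound 3 (0.54 log units; beyond the scatter) and so clears the usual scatter, which no earlier comparison could show. The gain comes with a larger group, although the hydrogen-bond donor and acceptor counts printed for the two groups match, so those counts alone do not separate compound 1 from compound 3. No measurement here explains why the half-life changes.

With a single step at this position, the compounds shown leave open whether the gain comes from adding methylcarbamoyl or from losing hydroxy. A plain hydrogen, a methoxy group, an unsubstituted carboxamide or a longer chain on the amide nitrogen at this carbon would help tell these apart.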